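Cyclohexyl acyl thiourea: expected cytotoxicity from two neighbours

This account rests on a few compounds, and the source may have more. Where it says the series, first, only, none or still open, it means among the compounds named here.

Working notes on the series. Compound 1 `NC(=S)N1CCCc2c(OCCCCCOc3cccc4ccccc34)cccc21` carries an unsubstituted thiourea. In an ADME assay on Huh-7 cells (Homo sapiens) for cytotoxicity (on this read-out higher numbers stand for lower toxicity in this test and lower numbers for higher toxicity in this test), compound 1 reports only a limit, > 50000 nM. Within the data shown here, compound 2 `N#Cc1cccc(C(=O)NC(=S)N2CCc3c(OCCCCCOc4ccc(Cl)cc4)cccc32)c1` carries a (3-cyanophenyl)carbonyl on the thiourea nitrogen and is the only member with a number in this assay: compound 2 gives 9750 nM. Compound 3 `CC(C)(C)c1ccc(C(=O)NC(=S)N2CCc3c(OCCCCCOc4ccc(Cl)cc4)cccc32)cc1` likewise reports only a limit in this assay, > 50000 nM. Among the measured compounds shown here, the one measured step in place is an at least 5.1-fold higher number from compound 2 to compound 3 (0.70 log units; beyond the scatter), so exchanging the aryl on the carbonyl carbon moved the read-out toward lower toxicity by an at least modest amount.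

Compound 4 `O=C(NC(=S)N1CCc2c(OCCCCCOc3ccc(Cl)cc3)cccc21)C1CCCCC1` is not yet measured. Relative to compound 2 the change is cyclohexyl in place of 3-cyanophenyl on a carbonyl carbon. For the measured compounds named here, the only step that bears on it is the one from compound 2 to compound 3, at the same carbonyl carbon, and it was at least modest; a saturated cyclohexyl has no measured counterpart here. Compound 4 is therefore expected to sit somewhat toward lower toxicity than compound 2, with the estimated step of a 2.1-fold higher number from compound 2 to compound 4 (0.31 log units; beyond the scatter). Compound 4 is estimated at 20000 nM, range 6000 nM to 60000 nM; the upper end is open because of the limit of > 50000 nM in this assay, at which 2 of the 3 values shown sit.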

Compound 4, half-maximal cytotoxic concentration: > 50000 nM
Compound 4: a limit, no number; the forecaster's own chance of this, stated with the estimate: 40%; at least 2.5-fold (0.39 log units) between middle value and limit.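

At the carbonyl carbon, cyclohexyl in place of 3-cyanophenyl gives an at least 5.1-fold higher number from compound 2 to compound 4 (0.70 log units; beyond the scatter) in this assay, so the move toward lower toxicity is no longer tied to one aryl replacement: a saturated ring and 4-(tert-butyl)phenyl both give it. Compound 2 remains the only acyl thiourea shown with a number in this assay, and the step between the two replacements cannot be read, which leaves cyclohexyl and 4-(tert-butyl)phenyl unordered. Compound 4 reports a limit and not a number, as compound 3 does, so the full size of the step out of compound 2 stays unknown: the limit of > 50000 nM in this assay, at which 3 of the 4 values shown sit.

Still open, from the compounds shown here alone, is whether the lower number of compound 2 goes with the nitrile or with the aromatic ring that carries it, a question that a plain phenyl on the carbonyl carbon would address. Also open, going by these compounds, is whether a piperidinyl amine or a carboxylic acid at this carbonyl carbon would give a number in this assay or another limit.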